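Fluoro to Hydroxy on the Aromatic Ring of Compound 3

The source may report more compounds than this note shows. Statements on the series, on what has been measured and on what is new or still open speak of the compounds shown alone.

Compound 1 `C=CC[C@H]1C[C@]2([C@@H](C)Cc3ccc(OC)c(C(=O)NC)c3)OCOC2=CC1=O` — 1400 nM
Compound 2 `C=CC[C@H]1C[C@]2([C@@H](C)Cc3ccc(OC)c(NC(C)=O)c3)OCOC2=CC1=O` — 85 nM
Compound 3 `C=CC[C@H]1C[C@]2([C@@H](C)Cc3ccc(OC)c(F)c3)OCOC2=CC1=O` — 8 nM

In a functional assay on M14 cells (Homo sapiens) for antiproliferative activity, with a stated time of 72 h (a lower number here means a stronger inhibitor, a higher number a weaker inhibitor), compound 3 gives the lowest number of the three, an 11-fold lower number from compound 2 to compound 3 (1.03 log units; beyond the scatter) and a 180-fold lower number from compound 1 to compound 3 (2.24 log units; beyond the scatter). Compound 4 `C=CC[C@H]1C[C@]2([C@@H](C)Cc3ccc(OC)c(O)c3)OCOC2=CC1=O` carries hydroxy in place of fluoro on an aromatic carbon. Among the measured compounds shown here, no measured step swaps fluoro for hydroxy; the steps that bear on it show that the small fluoro outperformed the larger acetamido and methylcarbamoyl groups at this position, and the hydroxy brings one hydrogen-bond donor and one acceptor where fluoro had none. A moderate weakening is therefore expected: a 3.8-fold higher number from compound 3 to compound 4 (0.57 log units; beyond the scatter) in this assay, with the estimate for compound 4 at 30 nM, within 8 nM to 120 nM.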

Compound 4, half-maximal inhibitory concentration: 8 nM
For compound 4 the middle estimate is 3.8-fold (0.57 log units) above the measured one, within the range that was stated.
By their numbers in this assay, from the lowest: compounds 3 and 4 (each within the scatter of the next); then compound 2; then compound 1.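

In this assay, no change at the digits printed from compound 3 to compound 4 (within the scatter) shows that this aromatic carbon takes hydroxy, with its hydrogen-bond donor and acceptor, as readily as fluoro. Hydroxy also stands well clear of the two larger groups, with an 11-fold lower number from compound 2 to compound 4 (1.03 log units; beyond the scatter) and a 180-fold lower number from compound 1 to compound 4 (2.24 log units; beyond the scatter) in the same assay, so a hydrogen-bond donor and acceptor at this place do not by themselves bring the higher numbers of those compounds. Nothing measured here explains this result.

Going by these compounds, whether a small amine or a carboxylic acid on this carbon would keep the number as low as fluoro and hydroxy do stays open.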